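This account rests on a few compounds, and the source may have more. Where it says the series, first, only, none or still open, it means among the compounds named here.

The study compares three measured compounds on one core and a fourth on another. Compound 1 `C=CCn1ncc2c(CC)ncn2c1=O` carries an ethyl group on its core, and compound 3 `C=CCn1ncc2c(CCC)ncn2c1=O` differs from it by methyl in place of hydrogen on a saturated chain carbon, two bonds along the chain from an aromatic carbon. In a functional assay for inhibition, with Homo sapiens as the target (a lower number here means a stronger inhibitor, a higher number a weaker inhibitor), compound 1 gives only a limit, > 48000 nM. Compound 3 likewise reaches only a limit in this assay, > 48000 nM. The step that the two limits leave unreadable from compound 1 to compound 3 therefore cannot be read, since both ends of it are limits rather than numbers; this rests on (the limit of > 48000 nM in this assay, at which 3 of the 3 values shown sit).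

Compound 2 `CCCc1nc(C)c2c(CC)nnc(S)n12` sits on a different core, and the difference between the two cores is not broken down here. In this assay compound 2 also stops at a limit, > 48000 nM.

Compound 4 `CCc1nnc(S)n2c(C(C)CC)nc(C)c12`, not yet measured, differs from compound 2 by methyl in place of hydrogen on a saturated chain carbon bound to an aromatic carbon and a saturated chain carbon. Among the measured compounds shown here, this is the same kind of change as the one from compound 1 to compound 3, but the place is not the same: in compound 4 the added methyl sits on a saturated chain carbon bound to an aromatic carbon and a saturated chain carbon, whereas in compound 3 it sits on a saturated chain carbon two bonds along the chain from an aromatic carbon.

The expected step from compound 2 to compound 4 is a step that the limit leaves unreadable from compound 2 to compound 4, and this expectation rests on compound 2 showing only the limit > 48000 nM and on (the limit of > 48000 nM in this assay, at which 3 of the 3 values shown sit). Compound 4 is accordingly estimated at 60000 nM in this assay, expected to fall between 20000 nM and 200000 nM, most likely as another limit.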

Compound 4, half-maximal inhibitory concentration: > 48000 nM
Compound 4 gave a limit, no number (the forecaster's own chance of this, stated with the estimate: 85%); the middle value is on the limit's open side.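

As far as these compounds go, compound 4, like compound 2, gives only a limit in this assay, so no new step can be read between compound 2 and compound 4, and the effect of going from propyl to sec-butyl stays unknown. The compounds shown leave open at what concentration, if any, each of them inhibits, and whether either added methyl changes that: the limit of > 48000 nM in this assay, at which 4 of the 4 values shown sit.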